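This account rests on a few compounds, and the source may have more. Where it says the series, first, only, none or still open, it means among the compounds named here.

Of the compounds shown here, three sharing one core have been tested in a functional assay on A549 cells (Homo sapiens) for cytotoxicity, read by MTT assay, with a stated time of 48 h; a higher number here means a weaker inhibitor, a lower number a stronger inhibitor. Compound 1 `COc1cc(-c2nnc3n2NC(c2ccco2)C(C(=O)c2ccccc2C)S3)cc(OC)c1OC` gives 80000 nM. Compound 2 `COc1cc(C(=O)C2Sc3nnc(-c4cc(OC)c(OC)c(OC)c4)n3NC2c2ccco2)cc(OC)c1OC` gives 48300 nM. Compound 3 `COc1cc(-c2nnc3n2NC(c2ccco2)C(C(=O)c2ccc(F)c(F)c2)S3)cc(OC)c1OC` gives 93700 nM, the highest of the three numbers, although its gaps to the other two stay within the scatter. The step under study leads to compound 4 `COc1cc(-c2nnc3n2NC(c2ccco2)C(C(=O)c2cccc(Br)c2)S3)cc(OC)c1OC`, where (3-bromophenyl in place of 3,4-difluorophenyl on a carbonyl carbon). Every earlier change of the aryl group on that carbonyl carbon left this assay essentially unmoved: a 1.7-fold lower number from compound 1 to compound 2 (0.22 log units; within the scatter), a 1.2-fold higher number from compound 1 to compound 3 (0.07 log units; within the scatter) and a 1.9-fold higher number from compound 2 to compound 3 (0.29 log units; within the scatter). A further exchange of that aryl group is therefore expected to produce no step beyond the scatter, a 1.2-fold lower number from compound 3 to compound 4 (0.07 log units; within the scatter). Compound 4 is estimated at 80000 nM, with a likely range from 35000 nM to 180000 nM.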

Compound 4, half-maximal inhibitory concentration: 36900 nM
Compound 4: the middle estimate sits 2.2-fold (0.34 log units) above what was measured; low and high end bracket the measured number.
By their numbers in this assay, from the lowest: compounds 4, 2, 1 and 3 (each within the scatter of the next, the first and the last beyond it).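

In this assay, the aryl group on this carbonyl carbon now produces steps beyond the scatter, though only modest ones: a 2.5-fold lower number from compound 3 to compound 4 (0.40 log units; beyond the scatter) and a 2.2-fold lower number from compound 1 to compound 4 (0.34 log units; beyond the scatter). By contrast, a 1.3-fold lower number from compound 2 to compound 4 (0.12 log units; within the scatter) stays within the scatter, so 3-bromophenyl and 3,4,5-trimethoxyphenyl cannot be told apart here. Nothing available explains these steps. From the compounds shown here alone, whether an amine or a carboxylic acid on that aryl group, or a longer chain in its place, would move the number further remains open. So does the effect of changes elsewhere on the shared core.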